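This account rests on a few compounds, and the source may have more. Where it says the series, first, only, none or still open, it means among the compounds named here.

Measured compounds:

Compound 1 `CCCN(CCC)Cc1ccc(Cl)c(-c2ccccc2OC)c1`: in an assay on isolated protein for binding affinity to 5-hydroxytryptamine receptor 1B (Homo sapiens) (a lower number here means a stronger inhibitor, a higher number a weaker inhibitor), compound 1 gives > 10000 nM, which is a limit of the assay and not a number.
Compound 2 `COc1ccccc1-c1cc(C2CCN(C)C2)ccc1Cl`: in this assay compound 2 gives 12 nM.
Compound 3 `CCNCc1ccc(Cl)c(-c2ccccc2OC)c1`: in this assay compound 3 gives 210 nM.

Compound 3 has the highest number of the two that are numbers; compound 2 is nearest, with an 18-fold higher number from compound 2 to compound 3 (1.24 log units; beyond the scatter), and compound 1 sits at a limit (the limit of > 10000 nM in this assay, at which 1 of the 3 values shown sits). Compound 4 `COc1ccccc1-c1cc(CN(C)C)ccc1Cl` has not yet been measured. It differs from compound 3 by dimethylamino in place of ethylamino on a saturated chain carbon bound to an aromatic carbon. Within the data shown here, two measured steps bear on this change. The step of an at least 47-fold lower number from compound 1 to compound 3 (1.67 log units; beyond the scatter) shows that a change at the same place, from dipropylamino to ethylamino, gives a large difference. The step of an 18-fold higher number from compound 2 to compound 3 (1.24 log units; beyond the scatter) shows that the amine part matters strongly too. Neither step is the same change as going to dimethylamino, so the expectation is loose. The expected step in this assay is a 2.1-fold lower number from compound 3 to compound 4 (0.32 log units; beyond the scatter), modest and toward a lower number. For compound 4 the estimate in this assay is 100 nM, between 25 nM and 600 nM.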

Compound 4, inhibition constant: 830 nM
Compound 4: the middle estimate sits 8.3-fold (0.92 log units) below what was measured; the whole stated range lies below it.
By their numbers in this assay, from the lowest: compound 2; then compound 3; then compound 4. At a limit, above all of these: compound 1.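

In this assay, this place distinguishes between two small amines: a 4.0-fold higher number from compound 3 to compound 4 (0.60 log units; beyond the scatter). Ethylamino has a hydrogen-bond donor and dimethylamino has none, yet the compounds shown cannot say whether that difference accounts for the step. Replacing the 1-methylpyrrolidin-3-yl group opens a wide gap, a 69-fold higher number from compound 2 to compound 4 (1.84 log units; beyond the scatter), while compound 1 holds a limit and not a number, so an at least 12-fold lower number from compound 1 to compound 4 (1.08 log units; beyond the scatter) is only a bound: the limit of > 10000 nM in this assay, at which 1 of the 4 values shown sits.

Methylamino and diethylamino would help to show whether the donor or the size and shape of the alkyl groups on nitrogen tracks with the numbers in this assay. As far as these compounds go, it also remains open whether a pyrrolidine ring joined through its nitrogen to the same chain carbon would give a number closer to that of compound 2.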